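The source may hold more compounds than are shown below. What is called first, only, known or untested is meant among the compounds shown, and "the series" means these compounds.

Compound 1 `COc1ccc(-n2nc(Sc3ccc(Cl)cc3)cc(CC[C@@H](C)NC(=O)[C@H]3CNCC[C@@H]3c3ccc(Cl)cc3)c2=O)cc1` gives 2.4 nM in an assay on CHO cells for binding affinity to Melanocortin receptor 4 (Homo sapiens); on this read-out higher numbers stand for weaker inhibition and lower numbers for stronger inhibition. Within the data shown here, compound 2 `COc1ccc(-n2nc(Sc3ccc(Cl)cc3)cc(CC[C@@H](C)NC(=O)[C@H]3CNCC[C@@H]3c3cccc(F)c3)c2=O)cc1` gives 490 nM in this assay, the highest of the two numbers recorded; the only measured step, a 200-fold higher number from compound 1 to compound 2 (2.31 log units; beyond the scatter), swaps both the halogen and its position at once. Compound 3 `COc1ccc(-n2nc(Sc3ccc(Cl)cc3)cc(CC[C@@H](C)NC(=O)[C@H]3CNCC[C@@H]3c3ccccc3F)c2=O)cc1` differs from compound 2 by 2-fluorophenyl in place of 3-fluorophenyl on a saturated ring carbon. Among the measured compounds shown here, no measured step isolates a move of fluorine around the ring, so the direction of the change is open, and compound 3 is expected to stay near compound 2, with a 1.2-fold higher number from compound 2 to compound 3 (0.09 log units; within the scatter) as the estimated step. Compound 3 is estimated at 600 nM, in the range 100 nM to 3500 nM.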

Compound 3, half-maximal inhibitory concentration: 13 nM
Compound 3: the middle estimate sits 46-fold (1.66 log units) above what was measured, and the stated range ends above it.
By their numbers in this assay, from the lowest: compound 1; then compound 3; then compound 2.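

In this assay, the place of the fluorine on this phenyl ring matters on its own: 2-fluorophenyl and 3-fluorophenyl have the same atoms joined differently, yet the swap gives a large change (a 38-fold lower number from compound 2 to compound 3 (1.58 log units; beyond the scatter)). The 2-fluorophenyl group still falls short of 4-chlorophenyl on the same saturated ring carbon (a 5.4-fold higher number from compound 1 to compound 3 (0.73 log units; beyond the scatter)). Nothing available explains the effect of the fluorine's place. Still open, going by these compounds, is how much of that remaining step belongs to the halogen and how much to its place, for both change at once. Also open, on these data alone, is how an unsubstituted phenyl or a methoxyphenyl group would fare here.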